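Allyl to methoxymethyl: a small ether swap on a shared core

A few compounds are considered here, and "the series" means these few. Any claim that something is new, unique, unknown or untested is made for them only; others in the source may bear on it.

Compound 1 `C=CCOc1ccccc1C1CC(=O)c2ccccc2O1` is the starting point. In a functional assay on J774.A1 cells (Mus musculus) for inhibition, read by Griess assay, with stated times of 1 h and 24 h (a higher number here means a weaker inhibitor, a lower number a stronger inhibitor), compound 1 gives 38600 nM, the second highest of three numbers. Its nearest neighbour is compound 3 `CC(C)c1ccc(COc2ccccc2C2CC(=O)c3ccccc3O2)cc1`, which gives 28600 nM, and the furthest is compound 2 `O=C1CC(c2ccccc2O)Oc2ccccc21`, which gives 71300 nM. Neither gap separates the compounds: hydrogen in place of allyl on an oxygen on an aromatic ring brings a 1.8-fold higher number from compound 1 to compound 2 (0.27 log units; within the scatter), and 4-isopropylphenyl in place of vinyl on a saturated chain carbon bound to an oxygen on an aromatic ring brings a 1.3-fold lower number from compound 1 to compound 3 (0.13 log units; within the scatter).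

Compound 4 `COCOc1ccccc1C1CC(=O)c2ccccc2O1` is not yet measured. It differs from compound 1 as follows: methoxy in place of vinyl on a saturated chain carbon bound to an oxygen on an aromatic ring. Both measured steps touch the same site, one removing the allyl group altogether and one adding a large aryl ring in place of vinyl, and both stayed within the scatter. The swap of vinyl for methoxy is a smaller change in size than either, so no step beyond the scatter is expected in this assay from this exchange.

For compound 4 the estimate in this assay is therefore 40000 nM, with a range of 20000 nM to 80000 nM, which means an expected step of a 1.0-fold higher number from compound 1 to compound 4 (0.02 log units; within the scatter).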

Compound 4, half-maximal inhibitory concentration: 35200 nM
The estimate for compound 4 lay 1.1-fold (0.06 log units) above the measured number, and the stated range covers the measured number.
By their numbers in this assay, from the lowest: compounds 3, 4, 1 and 2 (each within the scatter of the next, the first and the last beyond it).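

In this assay, the step of a 1.1-fold lower number from compound 1 to compound 4 (0.04 log units; within the scatter) shows that methoxy in place of vinyl on a saturated chain carbon bound to an oxygen on an aromatic ring leaves the number within the scatter, even though methoxy brings a hydrogen-bond acceptor that vinyl lacks, and the step of a 1.2-fold higher number from compound 3 to compound 4 (0.09 log units; within the scatter) shows the same when methoxy stands in place of 4-isopropylphenyl, so these three groups cannot be told apart at this carbon. The new information lies in the step of a 2.0-fold lower number from compound 2 to compound 4 (0.31 log units; beyond the scatter), a modest one that is the first among the steps shown to pass beyond the scatter, whereas the step of a 1.8-fold higher number from compound 1 to compound 2 (0.27 log units; within the scatter) for allyl and hydrogen on the same oxygen stayed within it. No measurement shown here accounts for any of these steps.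

Going by these compounds, whether an amine or a carboxylic acid at this saturated chain carbon would carry the number beyond the scatter from compound 1 remains open. So does whether a longer chain carrying a methoxy group would behave as methoxymethyl does in compound 4.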